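Methyl Ester in Place of Methoxyphenyl Ester

The source may report more compounds than this note shows. Statements on the series, on what has been measured and on what is new or still open speak of the compounds shown alone.

Compound 2 `COc1ccc(C(=O)OC2(C(=O)Nc3ccc([N+](=O)[O-])cc3)CCCCC2)cc1` gives 40 nM in an ADME assay on WI-38 cells (Homo sapiens) for inhibition, read by MTT assay, with a stated time of 72 h; a higher number here means a weaker inhibitor, a lower number a stronger inhibitor. Compound 1 `Cc1ccc(C(=O)OC2(C(=O)Nc3ccc([N+](=O)[O-])cc3)CCCCC2)cc1` gives 32 nM and compound 3 `O=COC1(C(=O)Nc2ccc([N+](=O)[O-])cc2)CCCCC1` gives 46.3 nM, so compound 2 holds the second highest of the three numbers, nearest to compound 3 and furthest from compound 1, yet both gaps are within the scatter. Compound 4 `CC(=O)OC1(C(=O)Nc2ccc([N+](=O)[O-])cc2)CCCCC1` differs from compound 2 by methyl in place of 4-methoxyphenyl on a carbonyl carbon. Going by the values given here, the steps that bear on this are those in which the whole aryl group left the ester: a 1.2-fold higher number from compound 2 to compound 3 (0.06 log units; within the scatter) and a 1.4-fold higher number from compound 1 to compound 3 (0.16 log units; within the scatter), both within the scatter. Keeping a methyl at that carbonyl carbon should likewise produce no shift beyond the scatter in this assay. Compound 4 is therefore estimated at 45 nM, with a range from 20 nM to 100 nM. This estimate means an expected step of a 1.1-fold higher number from compound 2 to compound 4 (0.05 log units; within the scatter).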

Compound 4, half-maximal inhibitory concentration: 386 nM
For compound 4 the middle estimate is 8.6-fold (0.93 log units) below the measured one; the whole stated range lies below it.
By their numbers in this assay, from the lowest: compounds 1, 2 and 3 (each within the scatter of the next); then compound 4.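

The group on this carbonyl carbon does matter, since methyl stands apart from 4-methoxyphenyl (a 9.7-fold higher number from compound 2 to compound 4 (0.98 log units; beyond the scatter)), from hydrogen (an 8.3-fold higher number from compound 3 to compound 4 (0.92 log units; beyond the scatter)) and from 4-methylphenyl (a 12-fold higher number from compound 1 to compound 4 (1.08 log units; beyond the scatter)). Losing the aromatic ring cannot alone account for this, as compound 3 lacks that ring too and stays within the scatter of compounds 1 and 2. Nothing available explains why methyl behaves differently.

From the compounds shown here alone, whether the higher number belongs to methyl alone or carries over to a longer chain such as ethyl or propyl on this carbonyl carbon remains open. Going by these compounds, the effect of an amine at the same place is also open.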